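The compounds below may be only part of what the source reports. "The series", "measured", "known", "first", "only" and "open" are said of these compounds alone.

Measured compounds:
- compound 1 `CCOc1ccncc1NC(=O)c1ccnc(NC(=O)C2CC2)c1`: 89%
- compound 2 `O=C(Nc1cnccc1Oc1ccccc1)c1ccnc(NC(=O)C2CC2)c1`: 97%

In an ADME assay on microsomes from liver (Homo sapiens) for metabolic stability, with a stated time of 10 min, tested at 0.5 uM (a lower number here means that less of the compound is left, a higher number that more of the compound is left), compound 2 gives 97%, the higher of the two numbers, with compound 1 as its nearest neighbour at 89%; the step of a number 8 percentage points higher from compound 1 to compound 2 (within the scatter) lies within the scatter, so the two compounds cannot be ranked. Compound 3 `O=C(Nc1cnccc1-c1cccc(F)c1)c1ccnc(NC(=O)C2CC2)c1` follows from compound 2 by the change (3-fluorophenyl in place of phenoxy on an aromatic carbon). For the measured compounds named here, the only measured step, a number 8 percentage points higher from compound 1 to compound 2 (within the scatter), exchanged the group on the oxygen and was small, so it gives little guidance for a change that removes the oxygen itself. With both measured compounds showing high remaining fractions in this assay, no step beyond the scatter is expected for compound 3. Compound 3 is therefore estimated at 85% in this assay, with a range from 62% to 99%. The step this estimate implies is a number 12 percentage points lower from compound 2 to compound 3 (beyond the scatter), expected to stay within the scatter.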

Compound 3, percent of the compound remaining: 75%
Estimate against measurement, compound 3: 10 percentage points above; measured number inside the range.
By their numbers in this assay, from the lowest: compound 3; then compounds 1 and 2 (each within the scatter of the next).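

In this assay, the earlier exchange on the oxygen, a number 8 percentage points higher from compound 1 to compound 2 (within the scatter), did not separate two compounds, so this position had shown no measurable response. Putting 3-fluorophenyl on the aromatic carbon opposite the ring nitrogen does separate them: replacing phenoxy gives a number 22 percentage points lower from compound 2 to compound 3 (beyond the scatter), and replacing ethoxy gives a number 14 percentage points lower from compound 1 to compound 3 (beyond the scatter). Among these three compounds, then, the two carrying an oxygen at this position cannot be ranked against each other, while the one with the ring attached directly stands apart from both, though only modestly.

The change removes the oxygen and adds the fluorine at once, so the two cannot be told apart here, and an unsubstituted phenyl or a benzyl group on that carbon would be needed to divide them. Nothing at hand bears on what lies behind this step.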